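Piperidinyl amide variation on the shared core: compound 3

The source may hold more compounds than are shown below. What is called first, only, known or untested is meant among the compounds shown, and "the series" means these compounds.

Measured so far in a functional assay on PC-3 cells (Homo sapiens) for cytotoxicity, read by MTT assay, with a stated time of 48 h; on this read-out higher numbers stand for weaker inhibition and lower numbers for stronger inhibition:
compound 1 `CC1CCCCN1CC(=O)N1N=C(c2cc3ccccc3oc2=O)CC1c1ccccc1`: 36300 nM
compound 2 `CC1CCCN(CC(=O)N2N=C(c3cc4ccccc4oc3=O)CC2c2ccccc2)C1`: 28300 nM

Among the compounds with values here, compound 2 holds the lowest of the two numbers in this assay, but the only measured step, a 1.3-fold lower number from compound 1 to compound 2 (0.11 log units; within the scatter), is within the scatter, so the two compounds cannot be ordered.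

Compound 3 `NC(=O)C1CCN(CC(=O)N2N=C(c3cc4ccccc4oc3=O)CC2c2ccccc2)CC1` differs from compound 2 by 4-carbamoylpiperidin-1-yl in place of 3-methylpiperidin-1-yl on a saturated chain carbon bound to a carbonyl carbon. Within the data shown here, the one measured step concerns a move of the methyl on the same ring and not an exchange of the methyl for a carbamoyl group, so it bears on the new change only weakly; it showed no movement beyond the scatter. Nothing measured in the series speaks to a carbamoyl group at this position. The expected step is therefore none beyond the scatter, a 1.1-fold higher number from compound 2 to compound 3 (0.03 log units; within the scatter). Compound 3 is estimated at 30000 nM in this assay, with a range from 9000 nM to 100000 nM.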

Compound 3, half-maximal inhibitory concentration: 8310 nM
Compound 3: middle estimate off by 3.6-fold (0.56 log units), on the high side; measured number below the stated range.
By their numbers in this assay, from the lowest: compound 3; then compounds 2 and 1 (each within the scatter of the next).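

In this assay the group on a saturated chain carbon bound to a carbonyl carbon can shift the number beyond the scatter, which the step between the two methylpiperidine compounds did not show. 4-Carbamoylpiperidin-1-yl lowers the number against 3-methylpiperidin-1-yl (a 3.4-fold lower number from compound 2 to compound 3 (0.53 log units; beyond the scatter)) and against 2-methylpiperidin-1-yl (a 4.4-fold lower number from compound 1 to compound 3 (0.64 log units; beyond the scatter)), so the drop holds against both methyl-bearing rings. No measurement bears on why this change lowers the number.

The change alters both the substituent and its place on the ring, so the compounds shown leave open whether the drop belongs to the carbamoyl group or to the 4-position. 4-Methylpiperidin-1-yl would separate these two, while a carboxylic acid or a primary amine at the 4-position would test how far the carbamoyl group itself matters.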